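The source may hold more compounds than are shown below. What is called first, only, known or untested is meant among the compounds shown, and "the series" means these compounds.

Measured in a functional assay on A549 cells (Homo sapiens) for cytotoxicity, read by MTT assay, with a stated time of 72 h; a higher number here means a weaker inhibitor, a lower number a stronger inhibitor:
- compound 1 `COc1ncc(-c2ccc3nc(NC(=O)NCCN4CCCC4)nn3c2)cc1NS(=O)(=O)c1ccc(F)cc1`: 960 nM
- compound 2 `COc1ncc(-c2ccc3nc(NC(=O)NCCN4CCCCC4)nn3c2)cc1NS(=O)(=O)c1ccc(F)cc1`: 610 nM
- compound 3 `COc1ncc(-c2ccc3nc(NC(=O)NCCN(C)C)nn3c2)cc1NS(=O)(=O)c1ccc(F)cc1`: 800 nM

Compound 3, at 800 nM, cannot be separated from the other two, with a 1.2-fold lower number from compound 1 to compound 3 (0.08 log units; within the scatter) and a 1.3-fold higher number from compound 2 to compound 3 (0.12 log units; within the scatter). Compound 4 `COc1ncc(-c2ccc3nc(NC(=O)NCCN4CCN(C)CC4)nn3c2)cc1NS(=O)(=O)c1ccc(F)cc1` carries 4-methylpiperazin-1-yl in place of dimethylamino on a saturated chain carbon, two bonds along the chain from an amide-type nitrogen. The bearing evidence is the exchanges at this same place, those two steps and a 1.6-fold lower number from compound 1 to compound 2 (0.20 log units; within the scatter), all within the scatter. None of them involves 4-methylpiperazin-1-yl, so they guide only loosely. In this assay, no step beyond the scatter is therefore expected. The expected change is a 1.1-fold lower number from compound 3 to compound 4 (0.03 log units; within the scatter). Compound 4 is estimated at 750 nM, with an expected range from 350 nM to 1600 nM.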

Compound 4, half-maximal inhibitory concentration: 1050 nM
For compound 4 the middle estimate is 1.4-fold (0.15 log units) below the measured one; the range from low to high includes it.
By their numbers in this assay, from the lowest: compounds 2, 3, 1 and 4 (each within the scatter of the next).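

In this assay, 4-methylpiperazin-1-yl, a six-membered ring with a further nitrogen, cannot be separated from any of the three smaller amines at this place (a 1.3-fold higher number from compound 3 to compound 4 (0.12 log units; within the scatter)), (a 1.7-fold higher number from compound 2 to compound 4 (0.24 log units; within the scatter)) and (a 1.1-fold higher number from compound 1 to compound 4 (0.04 log units; within the scatter)). Across these four compounds, then, the step from an open dimethylamino to this larger ring leaves the cytotoxicity reading within the scatter, and the added ring nitrogen shows no separate effect. Nothing available here offers an explanation for this flat result. Still open, from the compounds shown here alone, is whether a morpholin-4-yl ring, a hydroxyl group or a carboxylic acid at this chain carbon would behave the same way, and whether a longer chain would.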